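Hydroxy in Place of Methylsulfanyl: Three Limits and an Expectation

A few compounds are considered here, and "the series" means these few. Any claim that something is new, unique, unknown or untested is made for them only; others in the source may bear on it.

Measured compounds in a functional assay for inhibition, with Homo sapiens as the target; on this read-out higher numbers stand for weaker inhibition and lower numbers for stronger inhibition:
compound 1 `CSc1nncc2c(C(C)C)ncn12` gives > 48000 nM, a limit of the assay;
compound 2 `CC(C)c1ncn2c(O)nncc12` gives > 48000 nM, likewise a limit;
compound 3 `CCCc1nc(C)c2c(C)nnc(SC)n12` gives > 48000 nM, again a limit.

None of these three is a number: the limit of > 48000 nM in this assay, at which 3 of the 3 values shown sit. Compound 2 differs from compound 1 by hydroxy in place of methylsulfanyl on an aromatic carbon, and the step that the two limits leave unreadable from compound 1 to compound 2 lies between two limits, so its size is not readable. Compound 3 rests on another core; how its core differs from that of compound 1 is not broken down here.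

Compound 4 `CCCc1nc(C)c2c(C)nnc(O)n12` has not been measured in this assay. It differs from compound 3 by hydroxy in place of methylsulfanyl on an aromatic carbon, the same kind of change as from compound 1 to compound 2, except that here the place is also para to a methyl group (1 heavy atom). The earlier step that the two limits leave unreadable from compound 1 to compound 2 offers no size to carry over. The step that the limit leaves unreadable from compound 3 to compound 4 is therefore expected to be small. Compound 4 is expected at about 80000 nM, within 30000 nM to 300000 nM, most likely reported again only as a limit.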

Compound 4, half-maximal inhibitory concentration: 14000 nM
The estimate for compound 4 lay 5.7-fold (0.76 log units) above the measured number; measured number below the stated range.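

In this assay, hydroxy in place of methylsulfanyl on an aromatic carbon gives an at least 3.4-fold lower number from compound 3 to compound 4 (0.53 log units; beyond the scatter), a step beyond the scatter that starts from a limit and not from a number. On the core of compound 3 the change therefore ends in a readable value, whereas on the core of compound 1 the same change ends in compound 2, which remains a limit. This does not show that the change carries over from one core to the other with a shared size, nor that the two cores respond differently, because the step on the core of compound 1 cannot be read: the limit of > 48000 nM in this assay, at which 3 of the 4 values shown sit.

The compounds shown leave open whether an amine, a methoxy group or a longer alkylsulfanyl chain on that aromatic carbon would also give a readable value. Which of the differences between the two cores goes with the readable value of compound 4 also stays open.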